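The compounds below may be only part of what the source reports. "The series", "measured", "known", "first", "only" and "open" are said of these compounds alone.

In a functional assay on HeLa cells (Homo sapiens) for inhibition (a higher number here means a weaker inhibitor, a lower number a stronger inhibitor), three compounds have been measured:
Compound 1 `O=C1C=CC(OCC(F)(F)F)N1c1ccccc1` gives > 100000 nM, which is a limit of the assay and not a number.
Compound 2 `O=C1C=CC(OC(C(F)(F)F)C(F)(F)F)N1c1ccc(Cl)cc1` gives 1890 nM.
Compound 3 `O=C1C=CC(OCC(F)(F)F)N1c1ccccc1F` gives 19300 nM.

Compound 1 thus stands at the top end of what this assay reports, as only a limit is known for it (the limit of > 100000 nM in this assay, at which 1 of the 3 values shown sits). The unmeasured compound 4 `O=C1C=CC(OCC(F)(F)F)N1c1ccc(Br)cc1` differs from compound 1 by bromo in place of hydrogen on an aromatic carbon. For the measured compounds named here, only one measured step bears on this change, and it also exchanges a hydrogen on the aryl ring for a halogen: an at least 5.1-fold lower number from compound 1 to compound 3 (0.71 log units; beyond the scatter). Compound 2 carries a chloro on the same ring but also a different ether, so its value can only be set beside the others, not read as a step. Taking the halogen step from compound 1 to compound 3 as the guide, compound 4 is expected to show a clearly lower number than compound 1 in this assay, an expected step of an at least 12-fold lower number from compound 1 to compound 4 (1.09 log units; beyond the scatter). The estimate for compound 4 is therefore 8000 nM, within a range from 2000 nM to 40000 nM.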

Compound 4, half-maximal inhibitory concentration: 7060 nM
For compound 4 the middle estimate is 1.1-fold (0.05 log units) above the measured one, within the range that was stated.
By their numbers in this assay, from the lowest: compound 2; then compound 4; then compound 3. At a limit, above all of these: compound 1.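

In this assay, bromo in place of hydrogen on an aromatic carbon, para to a large group, brings an at least 14-fold lower number from compound 1 to compound 4 (1.15 log units; beyond the scatter) and so shows that this position tolerates a much heavier halogen than fluoro while the number still falls. Taken with an at least 5.1-fold lower number from compound 1 to compound 3 (0.71 log units; beyond the scatter) as a second single replacement on the same ring, this shows that the lowering is not confined to fluoro. The two steps cannot be ranked against each other because compound 1 is known only as a limit: the limit of > 100000 nM in this assay, at which 1 of the 4 values shown sits.

As far as these compounds go, whether a methyl, an amine or a carboxylic acid on this aromatic carbon would lower the number as bromo does remains open. Also open, from the compounds shown here alone, is how chloro at this position would compare with bromo on the otherwise unchanged core of compound 1.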